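Tetrazolyl for fluoro on the hydroxypyridinone series

The source may report more compounds than this note shows. Statements on the series, on what has been measured and on what is new or still open speak of the compounds shown alone.

In an ADME assay on HEK293 cells (Homo sapiens) for cytotoxicity, read by MTT assay, with a stated time of 4 days (a higher number here means a weaker inhibitor, a lower number a stronger inhibitor), the measured compounds stand as follows.
Compound 1 `N#Cc1ccc(-c2c[nH]c(=O)c(O)c2)cc1`: only the limit > 100000 nM is reported.
Compound 2 `O=c1[nH]cc(-c2ccc(-c3nnn[nH]3)cc2)cc1O`: 80000 nM.
Compound 3 `O=c1[nH]c(-c2ccc(F)cc2)ccc1O`: only the limit > 100000 nM is reported.

Compound 3 thus sits at the upper limit of this assay, so its number is not known; with compound 2 near that limit as well, the series shows no strong inhibitor so far, see (the limit of > 100000 nM in this assay, at which 2 of the 3 values shown sit).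

The compound to be measured is compound 4 `O=c1[nH]c(-c2ccc(-c3nnn[nH]3)cc2)ccc1O`. The change from compound 3 is 1H-tetrazol-5-yl in place of fluoro on an aromatic carbon.

Going by the values given here, the only measured step that resembles it is an at least 1.2-fold lower number from compound 1 to compound 2 (0.09 log units; that floor lies within the scatter), where the 1H-tetrazol-5-yl entered in place of cyano on the core of compound 1, a different partner group on a differently substituted core. That step stayed within the scatter and ran from a limit to a number close to it. Nothing in the shown data suggests a larger movement for the tetrazolyl on the core of compound 3. The expected step of a number no higher from compound 3 to compound 4 (the limit leaves the size open) is therefore none beyond the scatter, and a reported limit rather than a number is quite possible. Compound 4 is estimated at 100000 nM, with a range from 50000 nM to 200000 nM.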

Compound 4, half-maximal inhibitory concentration: >= 28000 nM
Compound 4: no number, only a limit; the forecaster's own chance of this, stated with the estimate: 65%; the middle value does not contradict the limit.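

In this assay, compound 3 and compound 4 are both reported only as limits, so no step can be read between them. The compounds shown leave open whether 1H-tetrazol-5-yl in place of fluoro on this core changes the read-out at all, and where the actual values of compound 3 and compound 4 lie.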